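Chlorine on the sulfonyl phenyl in two cathepsin S series

The source may hold more compounds than are shown below. What is called first, only, known or untested is meant among the compounds shown, and "the series" means these compounds.

In an assay on isolated protein for inhibition of cathepsin S (Homo sapiens), read by fluorescence, with a stated time of 20 min (a lower number here means a stronger inhibitor, a higher number a weaker inhibitor), three compounds have been measured: compound 1 `N#CCNC(=O)[C@@H]1CN(S(=O)(=O)c2ccccc2)C[C@H]1C(=O)N1CCOCC1` gives 271 nM; compound 2 `N#CCNC(=O)[C@@H]1CN(S(=O)(=O)c2ccccc2Cl)C[C@H]1C(=O)N1CCOCC1` gives 12 nM; compound 3 `N#CC1(NC(=O)[C@@H]2C[C@@H](S(=O)(=O)c3ccccc3)CN2C(=O)c2ccccc2)CC1` gives 13 nM.

Compound 1 and compound 2 differ only by chloro in place of hydrogen on an aromatic carbon, and this gave a 23-fold lower number from compound 1 to compound 2 (1.35 log units; beyond the scatter). Compound 3 is built on a different core; the difference between the two cores is not broken down here. Its value sits within the usual scatter of compound 2.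

Compound 4 `N#CC1(NC(=O)[C@@H]2C[C@@H](S(=O)(=O)c3ccccc3Cl)CN2C(=O)c2ccccc2)CC1` carries the same change on the core of compound 3: chloro in place of hydrogen on an aromatic carbon. For the measured compounds named here, because a 23-fold lower number from compound 1 to compound 2 (1.35 log units; beyond the scatter) was large, a step of similar direction is expected here, tempered since only one example exists and the core is different. The expected step is an 8.7-fold lower number from compound 3 to compound 4 (0.94 log units; beyond the scatter). Compound 4 is expected to give about 1.5 nM, likely between 0.4 nM and 6 nM.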

Compound 4, half-maximal inhibitory concentration: 0.8 nM
The estimate for compound 4 lay 1.9-fold (0.27 log units) above the measured number; measured number inside the range.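

In this assay chloro in place of hydrogen on an aromatic carbon gave a 16-fold lower number from compound 3 to compound 4 (1.21 log units; beyond the scatter) and so carried over from one core to the other with little change in size: the same change on two cores in this assay, a 23-fold lower number (1.35 log units; beyond the scatter) from compound 1 to compound 2 and a 16-fold lower number (1.21 log units; beyond the scatter) from compound 3 to compound 4, 1.4-fold (0.14 log units) apart, within the scatter of two such steps.
In both pairs, then, the same single chlorine lowered the number by a similar amount, whichever of the two cores carried it.
For the compounds shown here, this rests on only two pairs in one assay, so it does not show why chloro has this effect or that it would hold on a further core.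
The compounds shown leave open whether methyl, methoxy or bromo in the same place would do the same, and whether chloro on another carbon of that ring would.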